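Naphthalen-1-yl in Place of Formylphenyl: Expected Inhibition

This account rests on a few compounds, and the source may have more. Where it says the series, first, only, none or still open, it means among the compounds named here.

In a functional assay on OVCAR-3 cells (Homo sapiens) for inhibition, read by sulforhodamine B assay, with a stated time of 48 h, tested at 10 uM (on this read-out higher numbers stand for more inhibition at the one concentration tested (going by the name of the read-out) and lower numbers for less inhibition), compound 1 `c1ccc(-c2cn3ccnc3c(-c3ccc4ncn(C5CCCCC5)c4c3)n2)cc1` gives 41.8% and compound 2 `O=Cc1ccc(-c2cn3ccnc3c(-c3ccc4ncn(C5CCCCC5)c4c3)n2)cc1` gives 23.7%. Compound 2 thus stands lowest of the two numbers, with compound 1 the nearest and higher. Among the compounds with values here, the one measured step, a number 18.1 percentage points lower from compound 1 to compound 2 (beyond the scatter), bears on the next change: compound 3 `c1ccc2c(-c3cn4ccnc4c(-c4ccc5ncn(C6CCCCC6)c5c4)n3)cccc2c1` differs from compound 2 by naphthalen-1-yl in place of 4-formylphenyl on an aromatic carbon. Within the data shown here, the formyl group leaves in this change, and compound 1 without it gives 41.8%; no measured step shows what the second carbon ring adds. Compound 3 is therefore expected to show a modest rise, a number 16.3 percentage points higher from compound 2 to compound 3 (beyond the scatter). Compound 3 is estimated at 40%, between 20% and 60%.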

Compound 3, a percentage reported as inhibition, at one concentration (the size of the read-out at that concentration, not a potency): 2.38%
Compound 3: middle estimate off by 37.6 percentage points, on the high side; the measured number lies below the stated range.
By their numbers in this assay, from the lowest: compound 3; then compound 2; then compound 1.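

At this position on the shared core, in this assay, the number is lower with a second carbon ring: naphthalen-1-yl in place of phenyl gives a number 39.4 percentage points lower from compound 1 to compound 3 (beyond the scatter) and naphthalen-1-yl in place of 4-formylphenyl gives a number 21.3 percentage points lower from compound 2 to compound 3 (beyond the scatter). Losing the formyl group therefore did not by itself bring the number back, and compound 3 stands lowest of the three. Nothing available here explains this drop. The compounds shown leave open whether naphthalen-2-yl would fall as far, and how a phenyl carrying an amine or a carboxylic acid would read.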